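A few compounds are considered here, and "the series" means these few. Any claim that something is new, unique, unknown or untested is made for them only; others in the source may bear on it.

In a physicochemical assay for lipophilicity, read by HPLC, with a stated time of 90 min, tested at 100 uM (a higher number here means a more lipophilic compound, a lower number a more polar compound), compound 1 (`O=C(Nc1ccc(OC(F)(F)F)cc1)NC1CCN(C(=O)[C@@H]2CCOC2)CC1`) gives 3.38 against compound 2 (`O=C(Nc1ccc(OC(F)(F)F)cc1)NC1CCN(C(=O)C2CCOC2)CC1`) at 3.22 and compound 3 (`O=C(Nc1ccc(OC(F)(F)F)cc1)NC1CCN(C(=O)c2ccoc2)CC1`) at 3.63 on the same scale. Compound 1 sits within the scatter of both others, through the steps (a number 0.16 log units lower from compound 1 to compound 2 (within the scatter)) and (a number 0.25 log units higher from compound 1 to compound 3 (within the scatter)). Within the data shown here, only the step (a number 0.41 log units higher from compound 2 to compound 3 (beyond the scatter)) goes beyond the scatter. Compound 4 (`O=C(Nc1ccc(OC(F)(F)F)c(F)c1)NC1CCN(C(=O)[C@@H]2CCOC2)CC1`) differs from compound 1 elsewhere (fluoro in place of hydrogen on an aromatic carbon), with fluoro in place of hydrogen on an aromatic carbon, ortho to a trifluoromethoxy group. Among the measured compounds shown here, none of the measured steps touches that place, so they guide the expected size only loosely. In this assay a small upward step within the scatter is expected (a number 0.17 log units higher from compound 1 to compound 4 (within the scatter)). Compound 4 is estimated at 3.55 (range 3.25 to 3.85).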

Compound 4, partition coefficient: 3.59
For compound 4 the middle estimate is 0.04 log units below the measured one, and the stated range covers the measured number.
By their numbers in this assay, from the lowest: compounds 2, 1, 4 and 3 (each within the scatter of the next, the first and the last beyond it).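

The first change shown on the aromatic ring side of the molecule, fluoro in place of hydrogen on an aromatic carbon ortho to a trifluoromethoxy group, gives in this assay a number 0.21 log units higher from compound 1 to compound 4 (within the scatter). At this position, then, this single-atom change leaves the read-out indistinguishable from that of compound 1. The compounds shown offer nothing that accounts for the size of this step.

As far as these compounds go, whether a methyl, a chloro or an amine at this carbon would give a step beyond the scatter stays open. So does whether fluoro gives a similar step with furan-3-yl on the carbonyl carbon.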